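The source may report more compounds than this note shows. Statements on the series, on what has been measured and on what is new or still open speak of the compounds shown alone.

Of the compounds shown here, three with a shared core have been measured so far in a physicochemical assay for solubility, at pH 6.5; a lower number here means a less soluble compound, a higher number a more soluble compound. Compound 1 `CCc1nc2nc(C)cc(Nc3cccc(Cl)c3)n2n1` gives 170000 nM, compound 3 `Cc1cc(Nc2ccc(C(F)(F)F)cc2)n2nc(C3CC3)nc2n1` gives 38000 nM, and compound 2 `Cc1cc(Nc2ccc(S(F)(F)(F)(F)F)cc2)n2nc(C3CC3)nc2n1` gives 16000 nM, the lowest of the three numbers. Compound 4 `Cc1cc(Nc2ccc(S(F)(F)(F)(F)F)cc2)n2nc(C(C)(F)F)nc2n1` differs from compound 2 in one place, with 1,1-difluoroethyl in place of cyclopropyl on an aromatic carbon.

For the measured compounds named here, no measured step covers this exchange. Going by the values given here, the only single-group step available is a 2.4-fold higher number from compound 2 to compound 3 (0.38 log units; beyond the scatter), a modest change made elsewhere in the molecule. It bears on the question only indirectly, by showing how large one group exchange can be in this small set. Compound 1 differs from compound 2 in more than one place, so it cannot isolate the change. With no basis for a direction, no shift beyond the scatter is expected in this assay. The expected step is a 1.1-fold lower number from compound 2 to compound 4 (0.06 log units; within the scatter). For compound 4 the estimate is 14000 nM, with an expected range from 5500 nM to 36000 nM.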

Compound 4, solubility: 30000 nM
Beside the measured number, compound 4's estimate is 2.1-fold (0.33 log units) below it; the measured number falls inside the stated range.
By their numbers in this assay, from the lowest: compounds 2, 4 and 3 (each within the scatter of the next, the first and the last beyond it); then compound 1.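

For the compounds shown here, compound 4 gives the only direct reading of a change at this aromatic carbon of the five-membered ring: in this assay, the exchange gives a 1.9-fold higher number from compound 2 to compound 4 (0.27 log units; within the scatter). With the rest of compound 2 held fixed, an open 1,1-difluoroethyl group can therefore replace the cyclopropyl ring without a change in the number that stands beyond the scatter, even though the entering group has fluorine atoms and no ring. No supporting data bear on why the two groups read alike, so the result stays a plain observation.

On these data alone, it remains open whether the same exchange would read alike in the trifluoromethyl compound 3, whose other group differs from that of compound 2. As far as these compounds go, how an amine, a carboxylic acid or a longer chain on this same aromatic carbon would read in this assay also remains open.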